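The source may hold more compounds than are shown below. What is called first, only, known or untested is meant among the compounds shown, and "the series" means these compounds.

Measured so far:
Compound 1, `NS(=O)(=O)NCCCC[C@H](NC(=O)OCc1ccc(Cl)cc1)C(=O)Nc1nc(-c2ccccc2)cs1`, 530 nM.
Compound 2, `NS(=O)(=O)NCCCC[C@H](NC(=O)OCc1cccc(Cl)c1)C(=O)Nc1nc(-c2ccccc2)cs1`, 280 nM.

Both compounds were tested in an assay for inhibition of protein deacetylase HDAC6 (Homo sapiens); a lower number here means a stronger inhibitor, a higher number a weaker inhibitor. Among the measured compounds shown here, compound 2 has the lowest number of the two, and its only neighbour, compound 1, differs from it in one place: a 1.9-fold lower number from compound 1 to compound 2 (0.28 log units; within the scatter). So the two measured values lie within the scatter of each other, and nothing in the numbers separates them.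

Compound 3, `CCOC(=O)N[C@@H](CCCCNS(N)(=O)=O)C(=O)Nc1nc(-c2ccccc2)cs1`, has not yet been measured. It differs from compound 2 by methyl in place of 3-chlorophenyl on a saturated chain carbon bound to an oxygen next to a carbonyl group; read one bond further out, this is 3-chlorobenzyl to ethyl. For the measured compounds named here, the one measured step, from compound 1 to compound 2, only moves the chlorine within the aromatic ring and stays within the scatter, so it says nothing about taking the whole ring away. Going by the values given here, no measured pair shows what that does. Without a guide, the estimate leans toward a weaker inhibitor: the step from compound 2 to compound 3 is expected to be a 3.2-fold higher number from compound 2 to compound 3 (0.51 log units; beyond the scatter). Compound 3 is therefore estimated at 900 nM, with a range from 250 nM to 3500 nM.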

Compound 3, half-maximal inhibitory concentration: 200 nM
Estimate against measurement, compound 3: 4.5-fold (0.65 log units) above; measured number below the stated range.
By their numbers in this assay, from the lowest: compounds 3, 2 and 1 (each within the scatter of the next, the first and the last beyond it).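

In this assay the whole 3-chlorophenyl can give way to methyl at this place, on a saturated chain carbon bound to an oxygen next to a carbonyl group, and the result is a 1.4-fold lower number from compound 2 to compound 3 (0.15 log units; within the scatter) with no change that the numbers can separate from scatter. The same exchange made from the other chlorine placement, methyl in place of 4-chlorophenyl, gives a 2.7-fold lower number from compound 1 to compound 3 (0.42 log units; beyond the scatter) and is a modest gain for the ethyl carbamate. Across these three compounds, then, the aromatic ring and its chlorine are not needed to hold the number at this place, even though the group that enters has 1 heavy atom against 7, and nothing measured here explains this.

Going by these compounds, what lies between these two extremes stays open: a plain benzyl without chlorine, or a propyl or butyl chain in place of ethyl, could show whether the number moves gradually with the group or hardly at all. Whether an amine or a carboxylic acid at the end of this chain is tolerated is also unknown from the compounds shown.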